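The source may hold more compounds than are shown below. What is called first, only, known or untested is meant among the compounds shown, and "the series" means these compounds.

Measured compounds:
compound 1, `CC1=C(C(=O)Nc2ccc(Br)cc2)C(c2ccc(Cl)cc2Cl)N=C(SCc2ccc(Cl)cc2)N1`: 6.7% in a functional assay on the whole organism (artery, strain albino) with Rattus norvegicus as the target, with a stated time of 30 min, at a dose of 10 mg/kg by the oral route; on this read-out higher numbers stand for more inhibition at the one dose given (going by the name of the read-out) and lower numbers for less inhibition
compound 2, `CC1=C(C(=O)Nc2ccc(Br)cc2)C(c2ccc(Cl)cc2Cl)N=C(SCc2ccc(F)cc2)N1`: 7.7% in this assay
compound 3, `COc1ccc(C2N=C(SCc3ccc(Cl)cc3)NC(C)=C2C(=O)Nc2ccc(Br)cc2)cc1`: 7.2% in this assay

The three measured compounds share one core and differ in two places. Compound 3 differs from compound 1 by 4-methoxyphenyl in place of 2,4-dichlorophenyl on a saturated ring carbon; this is the difference between the two cores. In this assay the step is a number 0.5 percentage points higher from compound 1 to compound 3 (within the scatter). Compound 2 differs from compound 1 by fluoro in place of chloro on an aromatic carbon, and the step is a number 1 percentage points higher from compound 1 to compound 2 (within the scatter). All three values lie within the scatter of one another, so no order among them can be read from these numbers.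

Compound 4, `COc1ccc(C2N=C(SCc3ccc(F)cc3)NC(C)=C2C(=O)Nc2ccc(Br)cc2)cc1`, has not been measured in this assay. It differs from compound 3 by fluoro in place of chloro on an aromatic carbon. The place of this change, on an aromatic carbon of a six-membered aromatic ring of carbon only, para to a large group, reads word for word as for the change from compound 1 to compound 2, so the change is the same, made on a core that carries 4-methoxyphenyl in place of 2,4-dichlorophenyl. Compound 4 is expected to give 8%, with a range from 0% to 17%. The expected step, a number 0.8 percentage points higher from compound 3 to compound 4 (within the scatter), is estimated to be small because a number 1 percentage points higher from compound 1 to compound 2 (within the scatter) was itself within the scatter, and because a number 0.5 percentage points higher from compound 1 to compound 3 (within the scatter) shows the core change also moved the read-out little.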

Compound 4, a percentage reported as inhibition, in the whole organism at one dose (the size of the read-out at that dose, not a potency): 6.2%
For compound 4 the middle estimate is 1.8 percentage points above the measured one; measured number inside the range.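

In this assay, fluoro in place of chloro on the core of compound 3 gives a number 1 percentage points lower from compound 3 to compound 4 (within the scatter), and this step does not differ from the one on the core of compound 1: the same change on two cores in this assay, a number 1 percentage points higher (within the scatter) from compound 1 to compound 2 and a number 1 percentage points lower (within the scatter) from compound 3 to compound 4, 2 percentage points apart, within the scatter of two such steps

The change of core, 4-methoxyphenyl in place of 2,4-dichlorophenyl, gives a number 1.5 percentage points lower from compound 2 to compound 4 (within the scatter) with fluoro on board, and it also does not differ from the same change with chloro on board: the same change on two cores in this assay, a number 0.5 percentage points higher (within the scatter) from compound 1 to compound 3 and a number 1.5 percentage points lower (within the scatter) from compound 2 to compound 4, 2 percentage points apart, within the scatter of two such steps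

So within these four compounds both changes carry from one core to the other without a difference that can be read, but every step involved lies within the scatter, so this shows only that neither change moved the read-out measurably on either core, not that a change with a real effect would carry over, and the opposite signs of the two fluoro steps mean nothing.

Open, going by these compounds, is whether any group moves this read-out beyond the scatter at the one dose given, for example an amine or a carboxylic acid in place of the chloro or fluoro, or a longer chain in place of the (4-fluorobenzyl)sulfanyl group. Also open, on these data alone, is what the parts held constant across all four compounds contribute, since none of them varies here.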